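Aminophenyl for trimethoxyphenyl on the chain of compound 2

The compounds below may be only part of what the source reports. "The series", "measured", "known", "first", "only" and "open" are said of these compounds alone.

Measured so far in a functional assay on COLO 205 cells (Homo sapiens) for cytotoxicity, read by MTT assay, with a stated time of 72 h; a higher number here means a weaker inhibitor, a lower number a stronger inhibitor:
compound 1 `COc1ccc(C(=O)c2cc(OC)c(OC)c(OC)c2)cc1N`: 200 nM
compound 2 `COc1ccc(C(=O)c2cc(OC)c(OC)c(OC)c2)cc1NC(=O)/C=C/c1cc(OC)c(OC)c(OC)c1`: 5200 nM
compound 3 `COc1ccc(C(=O)c2cc(OC)c(OC)c(OC)c2)cc1NC(=O)/C=C/c1ccc(F)cc1`: 3400 nM

Compound 2 carries the highest of the three numbers in this assay. Compound 3 is the nearest to it, at a 1.5-fold lower number from compound 2 to compound 3 (0.18 log units; within the scatter), a gap within the scatter, so the two cannot be told apart. Compound 1 is the furthest from it, and the step of a 17-fold higher number from compound 1 to compound 3 (1.23 log units; beyond the scatter) shows that putting the substituent on the nitrogen on an aromatic ring is what moves the number far beyond the scatter.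

Compound 4 `COc1ccc(C(=O)c2cc(OC)c(OC)c(OC)c2)cc1NC(=O)/C=C/c1ccc(N)cc1` differs from compound 2 only in the group on the chain: 4-aminophenyl in place of 3,4,5-trimethoxyphenyl on a double-bonded chain carbon bound to a double-bonded chain carbon.

Among the compounds with values here, the one step that bears on this change is a 1.5-fold lower number from compound 2 to compound 3 (0.18 log units; within the scatter), an exchange of the same aryl group at the same place, and it stays within the scatter. The large step of a 17-fold higher number from compound 1 to compound 3 (1.23 log units; beyond the scatter) concerns a different part of the structure and does not speak to the aryl group. The expectation for compound 4 in this assay is therefore a step of a 1.3-fold lower number from compound 2 to compound 4 (0.11 log units; within the scatter), not beyond the scatter. Compound 4 is estimated at 4000 nM, with a range from 1500 nM to 12000 nM.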

Compound 4, half-maximal inhibitory concentration: 10300 nM
Estimate against measurement, compound 4: 2.6-fold (0.41 log units) below; measured number inside the range.
By their numbers in this assay, from the lowest: compound 1; then compounds 3, 2 and 4 (each within the scatter of the next, the first and the last beyond it).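

In this assay the group on the chain now gives one step beyond the scatter: amino in place of fluoro on an aromatic carbon produces a 3.0-fold higher number from compound 3 to compound 4 (0.48 log units; beyond the scatter) while 4-aminophenyl in place of 3,4,5-trimethoxyphenyl produces a 2.0-fold higher number from compound 2 to compound 4 (0.30 log units; within the scatter) and stays within it. The position is therefore not silent, yet compound 2 and compound 4 cannot be told apart, and only the amino and fluoro pair separates. Within the data shown here, the substituent on the nitrogen remains the dominant change, with a 52-fold higher number from compound 1 to compound 4 (1.71 log units; beyond the scatter) as the widest gap so far.

Still open, from the compounds shown here alone, is whether a carboxylic acid or a hydroxyl on that aromatic carbon would fall with compound 3 or compound 4, and whether a saturated chain on the nitrogen would come back towards compound 1. Nothing measured here accounts for these steps.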